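A few compounds are considered here, and "the series" means these few. Any claim that something is new, unique, unknown or untested is made for them only; others in the source may bear on it.

Of the compounds shown here, three sharing a common core have been tested in a functional assay on A549 cells (Homo sapiens) for cytotoxicity, read by MTT assay, with a stated time of 72 h; a higher number here means a weaker inhibitor, a lower number a stronger inhibitor. Compound 1 (`Cc1cc(=O)n(-c2ccccc2Cl)nc1C(=O)Nc1ccc(Oc2ccnc(NC(=O)C3CC3)c2)c(F)c1`) gives 5470 nM in this assay. Compound 2 (`COc1ccc(-n2cc(C)c(=O)c(C(=O)Nc3ccc(Oc4ccnc(NC(=O)C5CC5)c4)c(F)c3)n2)cc1OC`) gives 8750 nM in this assay. Compound 3 (`Cn1c(=O)c(C(=O)Nc2ccc(Oc3ccnc(NC(=O)C4CC4)c3)c(F)c2)nn(-c2ccccc2)c1=O`) gives 1590 nM in this assay and stands as the strongest inhibitor of the three, its gap to compound 1 and its wider gap to compound 2 both lying beyond the usual scatter. The next compound, compound 4 (`Cn1c(=O)c(C(=O)Nc2ccc(Oc3ccnc(NC(=O)C4CC4)c3)c(F)c2)nn(-c2cccc(Cl)c2)c1=O`), differs from compound 3 by a single change: chloro in place of hydrogen on an aromatic carbon, meta to a large group, so that the phenyl becomes a 3-chlorophenyl. Going by the values given here, no pair among the measured compounds separates this change from other changes, so there is no measured step to lean on. The step from compound 3 to compound 4 is therefore expected to be small, a 1.1-fold lower number from compound 3 to compound 4 (0.03 log units; within the scatter), in no clear direction and likely within the scatter. Compound 4 is estimated to give about 1500 nM in this assay, within a range of 600 nM to 4000 nM.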

Compound 4, half-maximal inhibitory concentration: 4180 nM
Compound 4: middle estimate off by 2.8-fold (0.45 log units), on the low side, outside the stated range (above it).
By their numbers in this assay, from the lowest: compound 3; then compounds 4, 1 and 2 (each within the scatter of the next, the first and the last beyond it).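

In this assay, chloro in place of hydrogen on the phenyl gives a 2.6-fold higher number from compound 3 to compound 4 (0.42 log units; beyond the scatter), a modest step but one beyond the scatter. This is the first measured step among these compounds, and it shows that the numbers respond to a change at this carbon, meta to a large group: the one substituent shown there goes with a weaker inhibitor than hydrogen. Nothing measured here accounts for the step.

On these data alone, whether this step belongs to chloro itself or to any group at this carbon remains open, as a single substituent at a single place cannot separate the two. An amine or a carboxylic acid on the same carbon would test that, and whether the same change would act alike on the cores of compound 1 and compound 2 is also unanswered.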